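Chloro in place of hydrogen on compound 1

A few compounds are considered here, and "the series" means these few. Any claim that something is new, unique, unknown or untested is made for them only; others in the source may bear on it.

compound 1 (`Cc1cc(O)c(C=O)c2c1C(=O)Oc1c(O)c3c(c(C)c1O2)C(=O)CC(C)(C)O3`) 4.34 ug/mL
compound 2 (`Cc1cc(O)c(C=O)c2c1C(=O)Oc1c(cc3c(c1C)C(=O)CC(C)(C)O3)O2`) 11.7 ug/mL

In a functional assay on KKU-M139 cells (Homo sapiens) for cytotoxicity, read by MTT assay (a lower number here means a stronger inhibitor, a higher number a weaker inhibitor), compound 1 gives 4.34 ug/mL as the lower of the two numbers, and the gap to compound 2 at 11.7 ug/mL lies beyond the scatter. Compound 3 (`Cc1c2c(c(O)c3c1C(=O)CC(C)(C)O3)OC(=O)c1c(C)c(Cl)c(O)c(C=O)c1O2`) keeps the core of compound 1 with one change (chloro in place of hydrogen on an aromatic carbon), chloro in place of hydrogen on an aromatic carbon, ortho to a hydroxy group and ortho to a methyl group. For the measured compounds named here, no measured pair shows this change, so only a small move towards a lower number in this assay is expected, possibly within the scatter. The estimated step of a 1.4-fold lower number from compound 1 to compound 3 (0.13 log units; within the scatter) is therefore modest. Compound 3 is estimated at 3.2 ug/mL (expected range 1.3 ug/mL to 8 ug/mL).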

Compound 3, half-maximal inhibitory concentration: 5.21 ug/mL
For compound 3 the middle estimate is 1.6-fold (0.21 log units) below the measured one; low and high end bracket the measured number.
By their numbers in this assay, from the lowest: compounds 1 and 3 (each within the scatter of the next); then compound 2.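

In this assay, chloro in place of hydrogen on this aromatic carbon, ortho to a hydroxy group and ortho to a methyl group, gives a 1.2-fold higher number from compound 1 to compound 3 (0.08 log units; within the scatter) and so shows that this position accepts a chlorine atom with no change beyond the scatter. For the compounds shown here, this is the first reading at this position, and it is a single substituent on a single core. No measurement offered here bears on why the number holds.

The compounds shown leave open whether a larger or different group at this position, such as bromo, an amine or a carboxylic acid, would also leave the number in place. They also leave open whether chloro would give a similar step on compound 2.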